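The source may hold more compounds than are shown below. What is called first, only, known or untested is meant among the compounds shown, and "the series" means these compounds.

Compound 1 `COc1cc(N(C)CCN(C)C)c(NC(=O)/C=C\C(C)C)cc1Nc1nc(C)cc(-c2cn(C)c3ccccc23)n1` gives 1070 nM in a functional assay on A549 cells (Homo sapiens) for antiproliferative activity, read by MTT assay, with a stated time of 72 h; a lower number here means a stronger inhibitor, a higher number a weaker inhibitor. Compound 2 `CCC/C=C\C(=O)Nc1cc(Nc2nc(C)cc(-c3cn(C)c4ccccc34)n2)c(OC)cc1N(C)CCN(C)C` gives 329 nM in this assay. Compound 3 `COc1cc(N(C)CCN(C)C)c(NC(=O)/C=C\C(C)C)cc1Nc1nccc(-c2cn(C)c3ccc(F)cc23)n1` gives 6140 nM in this assay.

Compounds 1 and 2 share a core and differ only in propyl in place of isopropyl on a double-bonded chain carbon bound to a double-bonded chain carbon; that change produced a 3.3-fold lower number from compound 1 to compound 2 (0.51 log units; beyond the scatter). Compound 3 carries a different core; the difference between the two cores is not broken down here. In this assay compound 3 stands furthest from compound 2 and nearest to compound 1. Compound 4 `CCC/C=C\C(=O)Nc1cc(Nc2nccc(-c3cn(C)c4ccc(F)cc34)n2)c(OC)cc1N(C)CCN(C)C` has not yet been measured in this assay. It differs from compound 3 by propyl in place of isopropyl on a double-bonded chain carbon bound to a double-bonded chain carbon, the same change as from compound 1 to compound 2, made at the same place. Because the earlier step was a 3.3-fold lower number from compound 1 to compound 2 (0.51 log units; beyond the scatter), a step of similar size is expected here, although a single precedent on a different core is a thin basis. For compound 4 the expected step is a 3.2-fold lower number from compound 3 to compound 4 (0.51 log units; beyond the scatter). Compound 4 is therefore estimated at 1900 nM, with a likely range from 900 nM to 4500 nM.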

Compound 4, half-maximal inhibitory concentration: 1030 nM
Compound 4: the middle estimate sits 1.8-fold (0.27 log units) above what was measured, within the range that was stated.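

Propyl in place of isopropyl on a double-bonded chain carbon bound to a double-bonded chain carbon gave a 6.0-fold lower number from compound 3 to compound 4 (0.78 log units; beyond the scatter) in this assay, the same direction as on the core of compound 1. The two steps do not differ in size by more than the usual scatter of such measurements: the same change on two cores in this assay, a 3.3-fold lower number (0.51 log units; beyond the scatter) from compound 1 to compound 2 and a 6.0-fold lower number (0.78 log units; beyond the scatter) from compound 3 to compound 4, 1.8-fold (0.26 log units) apart, within the scatter of two such steps. Among the compounds shown here, this shows that the change carried over between these two cores, but with only two pairs it does not show that it would hold on any other core.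

The compounds shown leave open how a longer chain, such as hexyl, or a cyclopropyl ring would behave at this place. Going by these compounds, an amine at the end of the chain also remains open.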